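Lipophilicity notes on a fluorophenyl-pyrazole oxazolidinone series

The compounds below may be only part of what the source reports. "The series", "measured", "known", "first", "only" and "open" are said of these compounds alone.

Measured compounds:
compound 1 `CN(CCC#N)C[C@H]1CN(c2ccc(-n3cc(-c4ccccn4)cn3)c(F)c2)C(=O)O1` — 1.9
compound 2 `O=C1CCC(=O)N1C[C@H]1CN(c2ccc(-n3cc(-c4ccccn4)cn3)c(F)c2)C(=O)O1` — 1.58
compound 3 `O=C(OC[C@H]1CN(c2ccc(-n3cc(-c4ccccn4)cn3)c(F)c2)C(=O)O1)c1ccccc1` — 4.21

In a physicochemical assay for lipophilicity, read by HPLC, measured as octanol-water partition (on this read-out higher numbers stand for higher lipophilicity and lower numbers for lower lipophilicity), compound 3 stands highest of the three, its nearest neighbour being compound 1, with compound 2 furthest away. The two measured steps that reach compound 3 are both large: a number 2.31 log units higher from compound 1 to compound 3 (beyond the scatter) and a number 2.63 log units higher from compound 2 to compound 3 (beyond the scatter). The third step, a number 0.32 log units lower from compound 1 to compound 2 (beyond the scatter), is modest by comparison.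

Compound 4 `COC(=O)NC[C@H]1CN(c2ccc(-n3cc(-c4ccccn4)cn3)c(F)c2)C(=O)O1` has not yet been measured in this assay. It differs from compound 3 in one place: (methoxycarbonyl)amino in place of benzoyloxy on a saturated chain carbon bound to a saturated ring carbon. Among the measured compounds shown here, the steps that bear on this change are the two that lead into compound 3, since in each the group that enters compound 3 is benzoyloxy and the group that leaves is a smaller substituent without a carbon-only ring. Running that change in reverse, a large drop is expected for compound 4, of about the same size as the two steps into compound 3, landing near the region where compound 1 and compound 2 sit. The estimated step is a number 2.51 log units lower from compound 3 to compound 4 (beyond the scatter). For compound 4 the expected value in this assay is 1.7, with a likely range from 1.2 to 2.3.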

Compound 4, partition coefficient: 2.03
The estimate for compound 4 lay 0.33 log units below the measured number; the measured number falls inside the stated range.
By their numbers in this assay, from the lowest: compound 2; then compounds 1 and 4 (each within the scatter of the next); then compound 3.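

At this place, on a saturated chain carbon bound to a saturated ring carbon, a third group replacing benzoyloxy now gives a large fall in this assay (a number 2.18 log units lower from compound 3 to compound 4 (beyond the scatter)), so compound 3 stands alone at the high end of all four compounds, and none goes against that. The three other groups do not share one level: (methoxycarbonyl)amino reads apart from 2,5-dioxopyrrolidin-1-yl (a number 0.45 log units higher from compound 2 to compound 4 (beyond the scatter)) but cannot be told from (2-cyanoethyl)(methyl)amino (a number 0.13 log units higher from compound 1 to compound 4 (within the scatter)). Going from benzoyloxy to (methoxycarbonyl)amino changes the carbon-only ring, the heavy atom count and the hydrogen-bond donor count together, and nothing at hand separates these changes or gives a reason for the size of the step.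

The compounds shown leave open whether benzoylamino, which keeps the carbon-only ring on a nitrogen link, would read with compound 3 or with compound 4. Also open, as far as these compounds go, is where acetoxy, a primary amine or a carboxylic acid would fall at this place, and whether the large gap belongs to the ring or to the ester link.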